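Methoxy for methyl on the anilino ring of compound 2

The source may report more compounds than this note shows. Statements on the series, on what has been measured and on what is new or still open speak of the compounds shown alone.

Measured so far:
Compound 1, `Nc1nc(Nc2ccc(F)cc2)sc1C(=O)c1ccccc1`, gives > 10000 nM in a functional assay on HeLa cells (Homo sapiens) for antiproliferative activity, read by cell counting, with a stated time of 2 days; a lower number here means a stronger inhibitor, a higher number a weaker inhibitor; this value is a limit of the assay, not a number.
Compound 2, `COc1cc(C(=O)c2sc(Nc3ccc(C)cc3)nc2N)cc(OC)c1OC`, gives 86 nM in this assay.

Going by the values given here, compound 2 therefore holds the only number in this assay among the two measured compounds; the other value is a limit, (the limit of > 10000 nM in this assay, at which 1 of the 2 values shown sits). Among the compounds with values here, no pair of measured compounds differs in a single place, so no measured step is available to lean on.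

Compound 3, `COc1ccc(Nc2nc(N)c(C(=O)c3cc(OC)c(OC)c(OC)c3)s2)cc1`, has not yet been tested in this assay. It differs from compound 2 in one place: methoxy in place of methyl on an aromatic carbon. The change swaps one small group for another on the ring bearing the amino link, leaving the shared core and the trimethoxyphenyl ketone untouched.

Within the data shown here, with no measured step to guide the size, the expectation is a small step in this assay, at most around the edge of the usual scatter, in either direction. The estimated step from compound 2 to compound 3 is a 1.4-fold lower number from compound 2 to compound 3 (0.16 log units; within the scatter). Compound 3 is expected to give about 60 nM, within a range of 20 nM to 200 nM.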

Compound 3, half-maximal inhibitory concentration: 560 nM
For compound 3 the middle estimate is 9.3-fold (0.97 log units) below the measured one; the measured number lies above the stated range.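

Before this result, no two measured compounds differed in a single place, so nothing showed how much the group on this aromatic carbon, para to a large group, matters in this assay. Replacing methyl with methoxy now gives a clear answer (a 6.5-fold higher number from compound 2 to compound 3 (0.81 log units; beyond the scatter)): since a higher number means a weaker inhibitor, compound 3 is the weaker of the pair, and this position is sensitive to even a small swap that brings in one oxygen and one hydrogen-bond acceptor. Nothing measured among these compounds explains why this step goes in this direction or why it is this large.

Going by these compounds, whether the oxygen itself matters stays open, and ethyl, which has a carbon where methoxy has its oxygen, would help to separate the presence of that oxygen from the longer group. Also open, on these data alone, is how a hydroxyl, an amine or a chlorine would behave at this position, and whether the same swap would cost as much with another ketone group, as compound 1 differs from both other compounds in more than one place.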